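Replacing the Chlorophenyl Ring with a Hydroxypyridinyl Ring

A few compounds are considered here, and "the series" means these few. Any claim that something is new, unique, unknown or untested is made for them only; others in the source may bear on it.

In an in vitro functional assay on HEK285-7 cells for antagonist activity at prostaglandin D2 receptor 2 (Homo sapiens), read by BRET and beta-arrestin recruitment (on this read-out lower numbers stand for stronger inhibition and higher numbers for weaker inhibition), the three measured compounds stand as follows: compound 1 `O=C(O)Cc1sc(C(c2ccccc2)c2ccc(F)cc2)nc1-c1ccc(Cl)cc1` gives 36 nM; compound 2 `O=C(O)Cc1sc(C(c2ccc(F)cc2)c2ccc(F)cc2)nc1-c1ccc(Cl)cc1` gives 180 nM; compound 3 `O=C(O)Cc1sc(C(c2ccccc2)c2ccccn2)nc1-c1ccc(Cl)cc1` gives 1900 nM.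

Compound 2 holds the second highest of these three numbers, separated from compound 1 by a 5.0-fold higher number from compound 1 to compound 2 (0.70 log units; beyond the scatter) and lying well below compound 3, whose number is higher still. Compound 4 `O=C(O)Cc1sc(C(c2ccc(F)cc2)c2ccc(F)cc2)nc1-c1ccnc(O)c1` differs from compound 2 by 2-hydroxypyridin-4-yl in place of 4-chlorophenyl on an aromatic carbon. Going by the values given here, no measured step alters this position of the shared core. Among the compounds with values here, the only aryl-to-heteroaryl exchange seen, a 53-fold higher number from compound 1 to compound 3 (1.72 log units; beyond the scatter), sat elsewhere and was large, while a 5.0-fold higher number from compound 1 to compound 2 (0.70 log units; beyond the scatter) was modest. Compound 4 is therefore expected to lose potency, a step of an 8.3-fold higher number from compound 2 to compound 4 (0.92 log units; beyond the scatter), giving an estimated 1500 nM within 300 nM to 8000 nM.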

Compound 4, half-maximal inhibitory concentration: 890 nM
Beside the measured number, compound 4's estimate is 1.7-fold (0.23 log units) above it; measured number inside the range.
By their numbers in this assay, from the lowest: compound 1; then compound 2; then compound 4; then compound 3.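

At this aromatic carbon, next to the ring nitrogen, swapping 4-chlorophenyl for 2-hydroxypyridin-4-yl gives a 4.9-fold higher number from compound 2 to compound 4 (0.69 log units; beyond the scatter), a modest change. So a ring of carbon only can give way here to one holding a hetero atom and a hydrogen-bond donor while the number stays below that of compound 3. No measurement at hand explains this step. Going by these compounds, whether the ring nitrogen or the hydroxy group accounts for the step stays open, as does how a plain pyridin-4-yl or a 4-methylphenyl group would read at this position.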